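A Chloro Group Added Beside Trifluoromethyl on the Urea Ring

The source may report more compounds than this note shows. Statements on the series, on what has been measured and on what is new or still open speak of the compounds shown alone.

Of the compounds shown here, three sharing one core have been tested in a functional assay on U-251 cells (Homo sapiens) for inhibition, read by sulforhodamine B assay, with a stated time of 48 h; on this read-out higher numbers stand for weaker inhibition of growth and lower numbers for stronger inhibition of growth. Compound 1 `O=C(Nc1cccc(-n2cc(-c3ccncc3)c(-c3ccc(Cl)c(O)c3)n2)c1)Nc1cccc(C(F)(F)F)c1` gives 1590 nM, the highest of the three numbers. Compound 2 `COc1cc(-c2nn(-c3cccc(NC(=O)Nc4cccc(C(F)(F)F)c4)c3)cc2-c2ccncc2)ccc1Cl` gives 645 nM in this assay, and compound 3 `O=C(Nc1cccc(-n2cc(-c3ccncc3)c(-c3ccc(Cl)c(O)c3)n2)c1)Nc1cc(C(F)(F)F)cc(C(F)(F)F)c1` gives 463 nM. The change from compound 1 to compound 2 is a methyl in place of hydrogen on an oxygen on an aromatic ring, giving a 2.5-fold lower number from compound 1 to compound 2 (0.39 log units; beyond the scatter). The change from compound 1 to compound 3 is a trifluoromethyl in place of hydrogen on an aromatic carbon, giving a 3.4-fold lower number from compound 1 to compound 3 (0.54 log units; beyond the scatter).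

Compound 4 `O=C(Nc1cccc(-n2cc(-c3ccncc3)c(-c3ccc(Cl)c(O)c3)n2)c1)Nc1ccc(Cl)c(C(F)(F)F)c1` differs from compound 1 by chloro in place of hydrogen on an aromatic carbon. The step from compound 1 to compound 3 bears most directly on this, since it also adds a group to the same ring, and the step from compound 1 to compound 2 shows that a small addition elsewhere also lowered the number. Both steps were modest and in the same direction, so a modest lowering is expected for compound 4 in this assay, roughly a 2.3-fold lower number from compound 1 to compound 4 (0.36 log units; beyond the scatter). Compound 4 is therefore estimated at 700 nM, within a range of 300 nM to 1800 nM.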

Compound 4, concentration for 50% growth inhibition: 548 nM
Beside the measured number, compound 4's estimate is 1.3-fold (0.11 log units) above it, and the stated range covers the measured number.
By their numbers in this assay, from the lowest: compounds 3, 4 and 2 (each within the scatter of the next); then compound 1.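

In this assay, a chloro group placed ortho to the trifluoromethyl group and para to a large group gives a 2.9-fold lower number from compound 1 to compound 4 (0.46 log units; beyond the scatter), so a single chlorine atom at this position is enough to lower the number. For the compounds shown here, until now, compound 3 was the only example of a lower number from an addition to this ring, and its added group was a second trifluoromethyl; compound 4 shows the same direction with a different and smaller group. The compounds come with no measurement that explains this drop.

As far as these compounds go, it remains open whether a fluoro, a methyl, a methoxy or an amine at this same place would lower the number as well. The compounds also leave open whether chloro would have the same effect on a ring without the trifluoromethyl group.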